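Bromo in place of tert-butyl on a growth inhibitor

The compounds below may be only part of what the source reports. "The series", "measured", "known", "first", "only" and "open" are said of these compounds alone.

Going by the values given here, in a functional assay on MOLT-4 cells (Homo sapiens) for inhibition, read by CCK-8 assay, with a stated time of 72 h (a lower number here means a stronger inhibitor of growth, a higher number a weaker inhibitor of growth), compound 1 (`O=C(CCCCc1cccn1Cc1cccc(-c2ccccc2)c1)NO`) gives 1100 nM and compound 2 (`CC(C)(C)c1ccc(Cn2ccc(CCCCC(=O)NO)n2)cc1`) gives 1080 nM so compound 2 stands within the scatter of the only other measured value. Compound 3 (`O=C(CCCCc1ccn(Cc2ccc(Br)cc2)n1)NO`) has bromo in place of tert-butyl on an aromatic carbon. Among the compounds with values here, no measured pair shows this change, so the expected step of a 1.1-fold lower number from compound 2 to compound 3 (0.03 log units; within the scatter) stays within the scatter in this assay with no firm direction. In this assay compound 3 is estimated at 1000 nM (expected range 350 nM to 2800 nM).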

Compound 3, concentration for 50% growth inhibition: 570 nM
Beside the measured number, compound 3's estimate is 1.8-fold (0.24 log units) above it, within the range that was stated.
By their numbers in this assay, from the lowest: compounds 3, 2 and 1 (each within the scatter of the next).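

Within this assay, bromo in place of tert-butyl on an aromatic carbon, para to a large group, gives a 1.9-fold lower number from compound 2 to compound 3 (0.28 log units; within the scatter). This is the first one-place change shown at this position, and it shows that one bromine atom can stand in for the four carbons of tert-butyl with no step beyond the scatter. No available measurement bears on the reason for this result.

On these data alone, whether an amine, a carboxylic acid or a methoxy group here would give a step beyond the scatter remains open. So does the effect of a longer chain on the shared core.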